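Sulfonyl chain extension on the thiourea series core

The source may report more compounds than this note shows. Statements on the series, on what has been measured and on what is new or still open speak of the compounds shown alone.

Compound 1 `CC1(C)CC(NC(=S)Nc2ccc(C#N)cc2)c2cc(NS(C)(=O)=O)ccc2O1` gives 11600 nM in a functional assay on thoracic aorta (Rattus norvegicus) for inhibition; on this read-out higher numbers stand for an effect only at larger amounts of compound and lower numbers for an effect already at smaller amounts. Compound 3 `CC1(C)CC(NC(=S)Nc2ccc(Cl)cc2)c2cc(NS(C)(=O)=O)ccc2O1` gives 11600 nM, and compound 2 `CC1(C)CC(NC(=S)Nc2cccc(Cl)c2)c2cc(NS(C)(=O)=O)ccc2O1` gives 9800 nM. Compound 1 stands level with compound 3 at the digits shown, the two together the highest of the three numbers, with compound 2 the furthest away; the three numbers all sit within the scatter of one another, as the step of no change at the digits printed from compound 1 to compound 3 (within the scatter), the step of a 1.2-fold lower number from compound 1 to compound 2 (0.07 log units; within the scatter) and the step of a 1.2-fold higher number from compound 2 to compound 3 (0.07 log units; within the scatter) show. Each of these measured steps alters only the aryl group on the amide-type nitrogen of the thiourea. Compound 4 `CCS(=O)(=O)Nc1ccc2c(c1)C(NC(=S)Nc1ccc(C#N)cc1)CC(C)(C)O2` differs from compound 1 elsewhere: methyl in place of hydrogen on a saturated chain carbon bound to a sulfonyl sulfur. Going by the values given here, no measured step touches the sulfonyl side of the shared core, so none of them bears directly on this change; what the series does show is that small changes so far have left the numbers within the scatter. For compound 4 the expectation in this assay is therefore no change at the digits printed from compound 1 to compound 4 (within the scatter), no step beyond the scatter. Compound 4 is estimated at 11600 nM, with a range from 5500 nM to 24000 nM.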

Compound 4, half-maximal effective concentration: 12000 nM
Beside the measured number, compound 4's estimate is 1.0-fold (0.01 log units) below it; the measured number falls inside the stated range.
By their numbers in this assay, from the lowest: compounds 2, 1, 3 and 4 (each within the scatter of the next).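

The sulfonyl side of the shared core now has a measured step of its own: in this assay, going from methanesulfonamido to (ethylsulfonyl)amino gives a 1.0-fold higher number from compound 1 to compound 4 (0.01 log units; within the scatter) and nothing larger. This position, on a saturated chain carbon bound to a sulfonyl sulfur, therefore accepts one added methyl without a step beyond the scatter, so the flat picture seen for the aryl changes among compound 1, compound 2 and compound 3 now extends to a second place on the molecule. No measurement at hand accounts for this result.

Still open, as far as these compounds go, is whether a propyl or longer chain, a phenyl, or a terminal amine or carboxylic acid on the sulfonyl group would stay within the scatter. Also open, from the compounds shown here alone, is whether the ethylsulfonyl change would read the same alongside the 3-chlorophenyl or 4-chlorophenyl thioureas.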